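This account rests on a few compounds, and the source may have more. Where it says the series, first, only, none or still open, it means among the compounds named here.

Compound 1, with the structure `CC(C)[C@H](NC(=O)c1cc(Cl)ccc1O)C(=O)Nc1ccc(Cl)cc1`, and compound 2, with the structure `C[C@H](NC(=O)c1cc(Cl)ccc1O)C(=O)Nc1cccc(Cl)c1`, share a core in which an amino acid-like fragment is capped on one side by a chlorinated hydroxybenzamide and on the other by a chlorinated aniline. In a functional assay on MCF7 cells (Homo sapiens) for cytotoxicity, with a stated time of 72 h (a lower number here means a stronger inhibitor, a higher number a weaker inhibitor), compound 1 reaches only the limit of > 10000 nM, which is a boundary of the assay rather than a number. In this assay compound 2 likewise stops at the limit of > 10000 nM, again a boundary and not a measured value. Compound 2 therefore stands at the limit of > 10000 nM in this assay, at which 2 of the 2 values shown sit, with nothing placing it above or below compound 1.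

Compound 3, with the structure `CC(C)[C@H](NC(=O)c1cc(Cl)ccc1O)C(=O)Nc1cccc(Cl)c1`, is reached from compound 2 through one change: isopropyl in place of methyl on a saturated chain carbon bound to an amide-type nitrogen and a carbonyl carbon. For the measured compounds named here, no measured pair in this set shows what such a change does, so the step is taken without a guide; a shift no larger than the usual scatter in this assay is expected, in no particular direction. Compound 3 is accordingly expected to sit near 20000 nM, within a range from 8000 nM to 50000 nM, which means an expected step that the limit leaves unreadable from compound 2 to compound 3.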

Compound 3, half-maximal inhibitory concentration: > 10000 nM
Compound 3: no number, only a limit; the forecaster's own chance of this, stated with the estimate: 85%; the middle value is on the limit's open side.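

In this assay compound 3 gives > 10000 nM, which is a limit and not a number. No step among compound 1, compound 2 and compound 3 can be read, because all three stop at the same limit: the limit of > 10000 nM in this assay, at which 3 of the 3 values shown sit.

The compounds shown leave open whether isopropyl or methyl, or 3-chlorophenyl or 4-chlorophenyl, makes any difference in this assay.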